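The source may report more compounds than this note shows. Statements on the series, on what has been measured and on what is new or still open speak of the compounds shown alone.

Compound 1 `COc1cc(NC(=O)Nc2cc(Nc3cc(F)ccc3OC)ncn2)cc(OC)c1` gives 42.1% in a functional assay on NCI-H1581 cells (Homo sapiens) for inhibition, read by MTT assay, with a stated time of 48 h, tested at 10 uM; on this read-out higher numbers stand for more inhibition at the one concentration tested (going by the name of the read-out) and lower numbers for less inhibition. Compound 2 `CCc1cccc(Nc2cc(NC(=O)Nc3cc(OC)cc(OC)c3)ncn2)c1` gives 27.7% in the same assay.

Among the measured compounds shown here, of the two numbers, compound 2 stands lowest; the only other number, that of compound 1, lies a number 14.4 percentage points lower from compound 1 to compound 2 (beyond the scatter) away, a change of the group on a nitrogen on an aromatic ring. Compound 3 `COc1cc(NC(=O)Nc2cc(Nc3ccc(OC)c(I)c3)ncn2)cc(OC)c1` changes the group on that same nitrogen again: 3-iodo-4-methoxyphenyl in place of 3-ethylphenyl on a nitrogen on an aromatic ring. For the measured compounds named here, the one measured step at this place was modest and beyond the scatter, and the group entering carries a methoxy, as compound 1 does. A modest rise, a number 9.3 percentage points higher from compound 2 to compound 3 (within the scatter), is therefore expected. Compound 3 is estimated at 37%, within 22% to 54%.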

Compound 3, a percentage reported as inhibition, at one concentration (the size of the read-out at that concentration, not a potency): 43%
Compound 3: the middle estimate sits 6 percentage points below what was measured; the measured number falls inside the stated range.
By their numbers in this assay, from the lowest: compound 2; then compounds 1 and 3 (each within the scatter of the next).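

In this assay, the group on this nitrogen moves the number in both directions: 3-iodo-4-methoxyphenyl in place of 3-ethylphenyl gives a number 15.3 percentage points higher from compound 2 to compound 3 (beyond the scatter), a second step of modest size at this place. Yet 3-iodo-4-methoxyphenyl in place of 5-fluoro-2-methoxyphenyl gives a number 0.9 percentage points higher from compound 1 to compound 3 (within the scatter), so two differently substituted rings land level. Among these compounds, the two groups carrying a methoxy sit together and the 3-ethylphenyl compound stands apart.

Nothing available explains these differences. Open, from the compounds shown here alone, is whether a ring is needed here at all, or whether a morpholine or a longer alkyl chain on this nitrogen would hold the number.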